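Hydroxy-methoxyphenyl variant of the aryl-pyridone series

A few compounds are considered here, and "the series" means these few. Any claim that something is new, unique, unknown or untested is made for them only; others in the source may bear on it.

Going by the values given here, compound 3 `COc1ccc(-c2cc(-c3cc(C(C)C)c(O)cc3C)[nH]c(=O)c2C#N)cc1` gives 47.5% in a functional assay for inhibition, tested at 80 ug/mL (on this read-out higher numbers stand for a stronger effect at the one concentration tested and lower numbers for a weaker effect), the lowest of the three numbers so far, though the gap to compound 2 `COc1ccc(-c2cc(-c3cc(C(C)C)c(O)cc3C)[nH]c(=O)c2C#N)c(OC)c1` at 55% is within the scatter; only compound 1 `Cc1cc(O)c(C(C)C)cc1-c1cc(-c2cccs2)c(C#N)c(=O)[nH]1` at 63% stands apart, as a number 15.5 percentage points lower from compound 1 to compound 3 (beyond the scatter). The step to compound 4 `COc1cc(-c2cc(-c3cc(C(C)C)c(O)cc3C)[nH]c(=O)c2C#N)ccc1O` is 4-hydroxy-3-methoxyphenyl in place of 4-methoxyphenyl on an aromatic carbon. Among the compounds with values here, the one measured step that touches this ring is a number 7.5 percentage points lower from compound 2 to compound 3 (within the scatter), and the other, a number 8 percentage points lower from compound 1 to compound 2 (within the scatter), also stayed within the scatter; the single step beyond it swapped the whole aryl group rather than its substituents. A step within the scatter is therefore expected, a number 2.5 percentage points higher from compound 3 to compound 4 (within the scatter). For compound 4 the estimate in this assay is 50%, with a range of 35% to 65%.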

Compound 4, a percentage reported as inhibition, at one concentration (the size of the read-out at that concentration, not a potency): 42%
Compound 4: the middle estimate sits 8 percentage points above what was measured; the measured number falls inside the stated range.
By their numbers in this assay, from the lowest: compounds 4, 3, 2 and 1 (each within the scatter of the next, the first and the last beyond it).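

Placing 4-hydroxy-3-methoxyphenyl on this aromatic carbon gives a number 5.5 percentage points lower from compound 3 to compound 4 (within the scatter) in this assay, so this hydroxy-bearing aryl group shows no gain over 4-methoxyphenyl. Going by these compounds alone, it is the first aryl group here to separate from 2,4-dimethoxyphenyl, with a number 13 percentage points lower from compound 2 to compound 4 (beyond the scatter), and the gap to thiophen-2-yl widens to a number 21 percentage points lower from compound 1 to compound 4 (beyond the scatter). No supporting measurement bears on these steps. Open, from the compounds shown here alone, is whether an amine or a carboxylic acid in place of the hydroxy would read differently, and whether furan-2-yl would match thiophen-2-yl.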